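A few compounds are considered here, and "the series" means these few. Any claim that something is new, unique, unknown or untested is made for them only; others in the source may bear on it.

Compound 1 `CC(=O)N[C@@H]1CCC[C@H](C(=O)Nc2cc(-c3cnn4c3CCCC4)c(F)cn2)C1`: < 3 mL.min-1.g-1
Compound 2 `CC(=O)N[C@@H]1CCC[C@H](C(=O)Nc2cc(-c3cnn4c3CCC4)c(Cl)cn2)C1`: < 3 mL.min-1.g-1

Both compounds were read in an ADME assay on microsomes from liver (Homo sapiens) for metabolic stability; on this read-out higher numbers stand for fast clearance and lower numbers for slow clearance. Compound 1 gives < 3 mL.min-1.g-1, which is a limit of the assay and not a number. Compound 2 gives < 3 mL.min-1.g-1, which is also a limit and not a number. Compound 2 therefore stands at the limit of < 3 mL.min-1.g-1 in this assay, at which 2 of the 2 values shown sit, and no measured number separates it from compound 1.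

Compound 3 `CC(=O)N[C@@H]1CCC[C@H](C(=O)Nc2cc(-c3cnn4c3CN(C)CC4)c(Cl)cn2)C1` departs from compound 2 on an aromatic carbon, ortho to a chloro group. The change is a group of 10 heavy atoms (7 carbon, 3 nitrogen; one five-membered aromatic ring with 2 hetero atoms, one six-membered non-aromatic ring with 2 hetero atoms) in place of a group of 8 heavy atoms (6 carbon, 2 nitrogen; one five-membered non-aromatic ring with 1 hetero atom, one five-membered aromatic ring with 2 hetero atoms), on an aromatic carbon. A six-membered non-aromatic ring with 2 hetero atoms enters where a five-membered non-aromatic ring with 1 hetero atom stood.

Within the data shown here, no measured step shows the effect of such a change in this assay. A small move towards faster clearance is expected, and it may stay within the scatter. The estimated change is an at least 1.3-fold higher number from compound 2 to compound 3 (0.12 log units; that floor lies within the scatter). For compound 3 the estimate is 4 mL.min-1.g-1, with an expected range from 2 mL.min-1.g-1 to 9 mL.min-1.g-1.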

Compound 3, intrinsic clearance in microsomes: < 3 mL.min-1.g-1
Compound 3: no number, only a limit; the forecaster's own chance of this, stated with the estimate: 50%; middle value at least 1.3-fold (0.12 log units) away from the limit.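

In this assay compound 3 gives only a limit and no number, as compound 2 does, so no step can be read between compound 2 and compound 3: the limit of < 3 mL.min-1.g-1 in this assay, at which 3 of the 3 values shown sit.

The compounds shown leave open whether the ring change alters clearance at all, and by how much.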